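A few compounds are considered here, and "the series" means these few. Any claim that something is new, unique, unknown or untested is made for them only; others in the source may bear on it.

Of the compounds shown here, three sharing one core have been measured in a functional assay on HeLa cells (Homo sapiens) for antiproliferative activity, read by cell counting, with a stated time of 3 days (a higher number here means a weaker inhibitor, a lower number a stronger inhibitor), and they differ only in the group on an oxygen on an aromatic ring. Compound 1 (`CC(Nc1ccccc1Oc1cccc(F)c1)=C1C(=O)CC(c2ccccc2)CC1=O`), with 3-fluorophenyl, gives 550 nM. Compound 2 (`CC(=O)c1ccc(Oc2ccccc2NC(C)=C2C(=O)CC(c3ccccc3)CC2=O)cc1`), with 4-acetylphenyl, gives 130 nM. Compound 3 (`CC(Nc1ccccc1Oc1ccc(C(C)O)cc1)=C1C(=O)CC(c2ccccc2)CC1=O`), with 4-(1-hydroxyethyl)phenyl, gives 75 nM. Compound 3 therefore stands level with compound 2, as the step of a 1.7-fold lower number from compound 2 to compound 3 (0.24 log units; within the scatter) lies within the scatter. The two 4-substituted groups both improve on 3-fluorophenyl, with modest steps of a 4.2-fold lower number from compound 1 to compound 2 (0.63 log units; beyond the scatter) and a 7.3-fold lower number from compound 1 to compound 3 (0.87 log units; beyond the scatter).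

Compound 4 (`CC(Nc1ccccc1Oc1cccc(N)c1)=C1C(=O)CC(c2ccccc2)CC1=O`) carries 3-aminophenyl in place of 4-(1-hydroxyethyl)phenyl on an oxygen on an aromatic ring. Within the data shown here, no measured compound carries this group, so no step speaks to it directly. The nearest guide is compound 1, whose group is also named as a 3-substituted phenyl and whose value is 550 nM. On that basis, part of the gain shown in a 7.3-fold lower number from compound 1 to compound 3 (0.87 log units; beyond the scatter) is expected to be lost, giving a modest move to a higher number in this assay. The expected step is a 2.9-fold higher number from compound 3 to compound 4 (0.47 log units; beyond the scatter). For compound 4 the estimated value is 220 nM, with an expected range of 70 nM to 700 nM.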

Compound 4, half-maximal inhibitory concentration: 82 nM
The estimate for compound 4 lay 2.7-fold (0.43 log units) above the measured number; the measured number falls inside the stated range.
By their numbers in this assay, from the lowest: compounds 3, 4 and 2 (each within the scatter of the next); then compound 1.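

In this assay, 3-aminophenyl cannot be told apart from either of the larger groups it was compared with: a 1.1-fold higher number from compound 3 to compound 4 (0.04 log units; within the scatter) against 4-(1-hydroxyethyl)phenyl and a 1.6-fold lower number from compound 2 to compound 4 (0.20 log units; within the scatter) against 4-acetylphenyl are both within the scatter. The earlier compounds shown here left it possible that only the two groups named with a 4 gave the lower numbers. Amino in place of fluoro on an aromatic carbon brings a 6.7-fold lower number from compound 1 to compound 4 (0.83 log units; beyond the scatter), although compound 1 and compound 4 both carry a group named with a 3. Nothing measured here explains why amino and fluoro differ so clearly at this place.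

From the compounds shown here alone, it remains open whether 4-aminophenyl would match 3-aminophenyl, which would show how much the placing of the amino group matters, and whether a hydroxyl or a methoxy group in its place would give a similar number. All four compounds also share the same core, so they cannot show whether 3-aminophenyl would hold its value if another part of the structure changed.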